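This account rests on a few compounds, and the source may have more. Where it says the series, first, only, none or still open, it means among the compounds named here.

Compound 1 `COc1cccc(/C=C/c2cc3c(c(=O)n(C)c(=O)n3C)n2C)c1` is the starting point here: in an assay on isolated protein for inhibition of Amine oxidase [flavin-containing] B (Homo sapiens), read by luminescence, with a stated time of 1 h (on this read-out lower numbers stand for stronger inhibition and higher numbers for weaker inhibition), compound 1 gives 370 nM. Compound 2 `Cn1c(=O)c2c(cc(/C=C/c3ccc(C(F)(F)F)cc3)n2C)n(C)c1=O` in this assay gives 432 nM. Compound 3 `Cn1c(=O)c2c(cc(/C=C/c3cccc(C#N)c3)n2C)n(C)c1=O` reaches only a limit of this assay, > 10000 nM, so no number is known for it. The step of an at least 27-fold higher number from compound 1 to compound 3 (1.43 log units; beyond the scatter) is large, and it rests on (the limit of > 10000 nM in this assay, at which 1 of the 3 values shown sits). Compound 4 `Cn1c(=O)c2c(cc(/C=C/c3ccc(C#N)cc3)n2C)n(C)c1=O` differs from compound 3 by 4-cyanophenyl in place of 3-cyanophenyl on a double-bonded chain carbon bound to a double-bonded chain carbon. Among the compounds with values here, no measured step covers this kind of move, and the one measured step concerns a different substituent, so it gives little guidance. Compound 4 is expected to give about 4000 nM, between 600 nM and 20000 nM. This estimated step, an at least 2.5-fold lower number from compound 3 to compound 4 (0.39 log units; beyond the scatter), is highly uncertain because compound 3 sits at > 10000 nM.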

Compound 4, half-maximal inhibitory concentration: 543 nM
Compound 4: middle estimate off by 7.4-fold (0.87 log units), on the high side; measured number outside the range, below it.
By their numbers in this assay, from the lowest: compounds 1, 2 and 4 (each within the scatter of the next). At a limit, above all of these: compound 3.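

The nitrile's placing on the ring matters here, and the change from 3-cyanophenyl to 4-cyanophenyl gives an at least 18-fold lower number from compound 3 to compound 4 (1.26 log units; beyond the scatter), though this step rests on a limit: the limit of > 10000 nM in this assay, at which 1 of the 4 values shown sits. The nitrile group as such is thus compatible with inhibition, since 4-cyanophenyl gives a 1.3-fold higher number from compound 2 to compound 4 (0.10 log units; within the scatter) and a 1.5-fold higher number from compound 1 to compound 4 (0.17 log units; within the scatter). Compound 1 also shows that a 3-substituted ring is not always poor, as its 3-methoxyphenyl group gives a measured 370 nM.

Still open, from the compounds shown here alone, is whether placing matters equally for methoxy or trifluoromethyl. Also open, going by these compounds, is how an amine or a carboxylic acid would read in place of the cyano on an aromatic carbon.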